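Aryl swap on the shared core: from compound 1 to compound 4

The source may report more compounds than this note shows. Statements on the series, on what has been measured and on what is new or still open speak of the compounds shown alone.

Measured so far:
- compound 1 `COc1ccccc1NC(=O)Nc1cccc(CNc2nccnc2Cl)c1`: 12200 nM
- compound 2 `O=C(Nc1cccc(Cl)c1)Nc1cccc(CNc2nccnc2Cl)c1`: 5330 nM
- compound 3 `O=C(Nc1cccc(CNc2nccnc2Cl)c1)Nc1ccc(F)c(Cl)c1`: 5020 nM

In a functional assay on MGC-803 cells (Homo sapiens) for antiproliferative activity, read by MTT assay, with a stated time of 48 h (on this read-out lower numbers stand for stronger inhibition and higher numbers for weaker inhibition), compound 1 stands at the highest number of the three. Its nearest neighbour is compound 2, with a 2.3-fold lower number from compound 1 to compound 2 (0.36 log units; beyond the scatter); compound 3 lies a little further out, with a 2.4-fold lower number from compound 1 to compound 3 (0.39 log units; beyond the scatter). Between compounds 2 and 3 the change is a 1.1-fold lower number from compound 2 to compound 3 (0.03 log units; within the scatter), so those two cannot be told apart on these numbers.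

Compound 4 `Cc1ccc(NC(=O)Nc2cccc(CNc3nccnc3Cl)c2)cc1Cl` is not yet measured. It differs from compound 1 in one place: 3-chloro-4-methylphenyl in place of 2-methoxyphenyl on an amide-type nitrogen. The two measured steps that bear on this are the same kind of swap on the same amide-type nitrogen, and both gave a modest lowering of the number beyond the scatter. The group entering in compound 4 carries the chloro seen in compounds 2 and 3, so a step of similar size and direction is expected in this assay.

For compound 4 the estimate is 5500 nM, with a range of 2500 nM to 12000 nM, meaning an expected step of a 2.2-fold lower number from compound 1 to compound 4 (0.35 log units; beyond the scatter).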

Compound 4, half-maximal inhibitory concentration: 17500 nM
Beside the measured number, compound 4's estimate is 3.2-fold (0.50 log units) below it; measured number outside the range, above it.
By their numbers in this assay, from the lowest: compounds 3 and 2 (each within the scatter of the next); then compounds 1 and 4 (each within the scatter of the next).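

In this assay, the chloro shared with compounds 2 and 3 does not by itself carry their gain: 3-chloro-4-methylphenyl in place of 2-methoxyphenyl on the amide-type nitrogen gives a 1.4-fold higher number from compound 1 to compound 4 (0.16 log units; within the scatter), so this swap has no readable effect. The methyl is the change that counts against activity, with a 3.3-fold higher number from compound 2 to compound 4 (0.52 log units; beyond the scatter) for methyl in place of hydrogen and a 3.5-fold higher number from compound 3 to compound 4 (0.54 log units; beyond the scatter) for methyl in place of fluoro, whereas fluoro in place of hydrogen gave only a 1.1-fold lower number from compound 2 to compound 3 (0.03 log units; within the scatter). No measurement at hand gives a cause for this difference between methyl and fluoro.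

From the compounds shown here alone, it remains open whether ethyl, trifluoromethyl or bromo in place of the methyl would track compound 4 or compound 3. Going by these compounds, it is also open whether a 4-methylphenyl without the chloro would show the same loss.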